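From methyl to carboxymethyl on an aromatic nitrogen

A few compounds are considered here, and "the series" means these few. Any claim that something is new, unique, unknown or untested is made for them only; others in the source may bear on it.

Measured in a functional assay (Homo sapiens) for inhibition, with a stated time of 72 h; on this read-out lower numbers stand for stronger inhibition and higher numbers for weaker inhibition:
- Compound 1 `COc1cc(C(=O)n2ccc3ccccc32)cc(OC)c1OC`: > 10000 nM
- Compound 2 `COc1cc(C(=O)c2ccc3c(ccn3C)c2)cc(OC)c1OC`: 12.5 nM

Compound 1 gives > 10000 nM as a limit of the assay, not a number. Compound 2 stands at 12.5 nM as the only true number shown. Compound 3 `COc1cc(C(=O)c2ccc3c(ccn3CC(=O)O)c2)cc(OC)c1OC` follows from compound 2 through carboxy in place of hydrogen on a saturated chain carbon bound to an aromatic nitrogen and so carries carboxy in place of hydrogen on a saturated chain carbon bound to an aromatic nitrogen. For the measured compounds named here, no measured step covers this change, so a weakening beyond the scatter in this assay is a judgement only. The expected 24-fold higher number from compound 2 to compound 3 (1.38 log units; beyond the scatter) is a clear loss of inhibition. Compound 3 is estimated at 300 nM with an expected range from 30 nM to 3000 nM in this read-out.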

Compound 3, half-maximal inhibitory concentration: 476 nM
Compound 3: the middle estimate sits 1.6-fold (0.20 log units) below what was measured; low and high end bracket the measured number.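

In this assay, for the compounds shown here, carboxy in place of hydrogen on a saturated chain carbon bound to an aromatic nitrogen gives a 38-fold higher number from compound 2 to compound 3 (1.58 log units; beyond the scatter), the only measured step at this position. The change therefore carries a clear cost, yet inhibition is not lost altogether. Compound 3 keeps a true number and does not fall to the limit that compound 1 gives: the limit of > 10000 nM in this assay, at which 1 of the 3 values shown sits.

On these data alone, it remains open whether the loss follows from the carboxy group itself or from the added chain. A methyl ester, a primary amide, a hydroxyethyl group or a longer chain ending in a carboxylic acid at this position could separate the two.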